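A few compounds are considered here, and "the series" means these few. Any claim that something is new, unique, unknown or untested is made for them only; others in the source may bear on it.

Measured compounds in a functional assay on the whole organism (Tail, strain ICR) with Mus musculus as the target, in the tail flick test, with a stated time of 90 min, at a dose of 25 umol/kg by the oral route; a lower number here means a weaker effect, a higher number a stronger effect of the compound at the dose given:

compound 1 `O=C(CN(c1nc(Cl)nc2[nH]cnc12)C1CC1)N[C@@H](CC(=O)OCc1ccccc1)C(=O)OCc1ccccc1` gives 15.6%
compound 2 `CC[C@H](C)[C@H](NC(=O)CN(c1ncnc2c1ncn2C1CCCCO1)C1CC1)C(=O)OCc1ccccc1` gives 22.6%
compound 3 `O=C(CN(c1ncnc2c1ncn2C1CCCCO1)C1CC1)NCC(=O)OCc1ccccc1` gives 25.9%

Compound 1 stands lowest of the three numbers in this assay; its nearest neighbour is compound 2, within the scatter, and only compound 3 lies beyond the scatter above it. Going by the values given here, the single step between measured compounds that differ in one place, a number 3.3 percentage points higher from compound 2 to compound 3 (within the scatter), exchanges a side chain on a saturated chain carbon and stays within the scatter; the two compounds concerned also carry a core different from that of compound 1.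

Compound 4 `NC(=O)C[C@H](NC(=O)CN(c1nc(Cl)nc2[nH]cnc12)C1CC1)C(=O)OCc1ccccc1` is the next compound to be measured. It differs from compound 1 by amino in place of benzyloxy on a carbonyl carbon. Among the compounds with values here, no measured step touches this position or this exchange, and the one step that is available, from compound 2 to compound 3, was within the scatter. There is therefore no basis for expecting a step beyond the scatter in this assay in either direction.

Compound 4 is expected to give about 16% in this assay, within roughly 5% to 30%, which is the estimated step of a number 0.4 percentage points higher from compound 1 to compound 4 (within the scatter).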

Compound 4, a percentage reported as activity, at one dose (the size of the read-out at that dose, not a potency): 32.3%
Compound 4: the middle estimate sits 16.3 percentage points below what was measured, outside the stated range (above it).
By their numbers in this assay, from the lowest: compounds 1, 2, 3 and 4 (each within the scatter of the next, the first and the last beyond it).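

In this assay, going by these compounds alone, amino in place of benzyloxy on a carbonyl carbon whose other neighbour is a saturated chain carbon gives a number 16.7 percentage points higher from compound 1 to compound 4 (beyond the scatter), the first step to go beyond the scatter. This position therefore responds to substitution, and the effect at the dose given survives the change from (benzyloxycarbonyl)methyl to carbamoylmethyl, so this benzyloxy group is not required for it. Nothing at hand explains the step.

From the compounds shown here alone, this single pair cannot separate the loss of the benzyloxy group from the entry of the amino group, and it remains open whether a carboxylic acid, a methyl ester or a methylamide at the same carbonyl carbon would read like compound 1 or like compound 4. Also open, going by these compounds, is whether the exchange carries over to the remaining benzyl ester of compound 4.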